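Swapping the amide's chloropyridine for plain pyridine

The source may report more compounds than this note shows. Statements on the series, on what has been measured and on what is new or still open speak of the compounds shown alone.

Measured so far:
- compound 1 `COc1cc(F)c(NC(=O)c2ccnc(Cl)c2)cc1Nc1nccc(-c2cn(C)c3ccccc23)n1`: 6890 nM
- compound 2 `COc1cc(N(C)CCN(C)C)c(NC(=O)c2ccnc(Cl)c2)cc1Nc1nccc(-c2cn(C)c3ccccc23)n1`: 970 nM

Both compounds were tested in a functional assay on A549 cells (Homo sapiens) for antiproliferative activity, read by MTT assay, with a stated time of 72 h; on this read-out higher numbers stand for weaker inhibition and lower numbers for stronger inhibition. Compound 2 holds the lowest of the two numbers; its nearest neighbour is compound 1, and that gap, a 7.1-fold lower number from compound 1 to compound 2 (0.85 log units; beyond the scatter), comes from placing (2-(dimethylamino)ethyl)(methyl)amino in place of fluoro on an aromatic carbon.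

Compound 3 `COc1cc(N(C)CCN(C)C)c(NC(=O)c2cccnc2)cc1Nc1nccc(-c2cn(C)c3ccccc23)n1` differs from compound 2 in a different region: pyridin-3-yl in place of 2-chloropyridin-4-yl on a carbonyl carbon. For the measured compounds named here, the one measured step, from compound 1 to compound 2, touches the aromatic core and not the amide, so no measured step bears on this change. With nothing to go on, the expectation for this assay is a step no larger than the scatter, in no fixed direction. Compound 3 is therefore estimated at 1200 nM, within 400 nM to 4000 nM, which is the expected step of a 1.2-fold higher number from compound 2 to compound 3 (0.09 log units; within the scatter).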

Compound 3, half-maximal inhibitory concentration: 1600 nM
For compound 3 the middle estimate is 1.3-fold (0.12 log units) below the measured one, and the stated range covers the measured number.
By their numbers in this assay, from the lowest: compounds 2 and 3 (each within the scatter of the next); then compound 1.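

In this assay, the amide end of the molecule now has a measured step of its own: pyridin-3-yl in place of 2-chloropyridin-4-yl on a carbonyl carbon gives a 1.6-fold higher number from compound 2 to compound 3 (0.22 log units; within the scatter) and so stays inside the usual scatter. For this pair, then, the ring on the carbonyl can lose its chlorine and change its point of attachment without a difference that can be read. No measured evidence speaks to the reason for this outcome. The swap combines those two edits, and a plain pyridin-4-yl on the same carbonyl carbon would be needed to separate them. As far as these compounds go, whether a phenyl ring or a carboxylic acid on that ring would move the number remains open.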